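The source may hold more compounds than are shown below. What is called first, only, known or untested is meant among the compounds shown, and "the series" means these compounds.

Compound 1 `C=C1C[C@]23C[C@@]1(O)CC[C@H]2c1ccc(O)c(C)c1[C@@H]3Cn1cc(-c2ccccc2)nn1` and compound 2 `C=C1C[C@]23C[C@@]1(O)CC[C@H]2c1cc(Br)c(O)c(C)c1[C@@H]3Cn1cc(-c2ccccc2)nn1` share one core; compound 2 carries bromo in place of hydrogen on an aromatic carbon. In a functional assay on MCF7 cells (Homo sapiens) for cytotoxicity, read by MTT assay, with a stated time of 4 days (on this read-out higher numbers stand for weaker inhibition and lower numbers for stronger inhibition), compound 1 gives only a limit of the assay, > 20000 nM. In this assay compound 2 likewise gives only a limit, > 20000 nM. The step that the two limits leave unreadable from compound 1 to compound 2 therefore cannot be read, because both values sit at the limit of > 20000 nM in this assay, at which 2 of the 2 values shown sit. Compound 3 `C=C1C[C@]23C[C@@]1(O)CC[C@H]2c1cc(Br)c(O)c(C)c1[C@@H]3Cn1cc(-c2ccc(C(F)(F)F)cc2)nn1` differs from compound 2 by trifluoromethyl in place of hydrogen on an aromatic carbon. Among the compounds with values here, with no measured step of readable size, no shift beyond the scatter is expected, and compound 3 is estimated at 30000 nM, between 8000 nM and 100000 nM, a step that the limit leaves unreadable from compound 2 to compound 3.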

Compound 3, half-maximal inhibitory concentration: 8100 nM
Compound 3: middle estimate off by 3.7-fold (0.57 log units), on the high side; the range from low to high includes it.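

Unlike the bromo step, which cannot be read, the change from phenyl to 4-(trifluoromethyl)phenyl registers in this assay: an at least 2.4-fold lower number from compound 2 to compound 3 (0.39 log units; beyond the scatter). Within the data shown here, compound 3 is therefore the first compound here to give a measured number rather than a limit. The true step may be larger, because compound 2 gives only a limit of the assay: the limit of > 20000 nM in this assay, at which 2 of the 3 values shown sit.

The compounds shown leave open whether a nitrile, a methoxy group or an amine at this place would shift the number similarly. They also leave open whether trifluoromethyl would have the same effect without the bromo.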